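The source may hold more compounds than are shown below. What is called first, only, known or untested is meant among the compounds shown, and "the series" means these compounds.

Among the compounds with values here, compound 2, `CC(C)[C@H](NC(=O)COc1cccc2ccccc12)C(=O)N[C@@H](CC(=O)O)C(=O)COc1c(F)cccc1F`, is the only compound of the pair with a number in a functional assay on Jurkat cells (Homo sapiens); on this read-out higher numbers stand for weaker inhibition and lower numbers for stronger inhibition: compound 2 gives 2040 nM. Compound 1, `CC(C)[C@H](NC(=O)COc1cccc2ccccc12)C(=O)N[C@@H](CC(=O)O)C(=O)COc1ccccc1[N+](=O)[O-]`, is reported in this assay only as a limit, > 100000 nM. Within the data shown here, the one measured step at this position is an at least 49-fold lower number from compound 1 to compound 2 (1.69 log units; beyond the scatter); its size rests on (the limit of > 100000 nM in this assay, at which 1 of the 2 values shown sits), so only its lower bound is known. Compound 3, `CC(C)[C@H](NC(=O)COc1cccc2ccccc12)C(=O)N[C@@H](CC(=O)O)C(=O)COc1c(F)c(F)c(F)c(F)c1F`, carries 2,3,4,5,6-pentafluorophenyl in place of 2,6-difluorophenyl on an oxygen on a saturated carbon. Among the measured compounds shown here, the step from compound 1 to compound 2 shows that the group on this oxygen moves the number strongly, but it set 2,6-difluorophenyl against 2-nitrophenyl, whereas compound 3 keeps a fluorinated ring and exchanges 2,6-difluorophenyl for 2,3,4,5,6-pentafluorophenyl; no measured step tells how that exchange acts. For the measured compounds named here, a smaller step than the one from compound 1 to compound 2, toward a lower number, is expected: a 2.0-fold lower number from compound 2 to compound 3 (0.31 log units; beyond the scatter). Compound 3 is therefore estimated at 1000 nM, within 250 nM to 4000 nM.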

Compound 3, half-maximal inhibitory concentration: 3050 nM
Estimate against measurement, compound 3: 3.1-fold (0.48 log units) below; the measured number falls inside the stated range.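

In this assay, exchanging 2,6-difluorophenyl for 2,3,4,5,6-pentafluorophenyl on this oxygen gives a 1.5-fold higher number from compound 2 to compound 3 (0.17 log units; within the scatter), so the two fluorinated rings cannot be told apart on this read-out. The second fluorinated ring also gives an at least 32-fold lower number from compound 1 to compound 3 (1.51 log units; beyond the scatter), so the large step away from 2-nitrophenyl is not confined to 2,6-difluorophenyl. Both steps from compound 1 are known only as lower bounds because compound 1 is reported as a limit: the limit of > 100000 nM in this assay, at which 1 of the 3 values shown sits.

Still open, on these data alone, is whether an unsubstituted phenyl, or a phenyl carrying a single fluorine, on this oxygen would give a number like those of compound 2 and compound 3 or move toward compound 1. As far as these compounds go, it is equally open whether a 2-aminophenyl or 2-methoxyphenyl ring would share the outcome of the 2-nitrophenyl ring.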